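Swapping the Methoxy-Bearing Ring of Compound 3

The compounds below may be only part of what the source reports. "The series", "measured", "known", "first", "only" and "open" are said of these compounds alone.

Three compounds share one core and differ only in the aromatic ring attached to a carbon double-bonded to nitrogen. Compound 1 `CN(C)CCn1cnnc1-c1cc(Oc2ccc(NC(=O)N/N=C/c3c(Cl)cccc3Cl)cc2F)ccn1` carries a 2,6-dichlorophenyl there; in a functional assay on A549 cells (Homo sapiens) for cytotoxicity, read by MTT assay, with a stated time of 72 h (a higher number here means a weaker inhibitor, a lower number a stronger inhibitor), compound 1 gives 1410 nM. Compound 2 `CN(C)CCn1cnnc1-c1cc(Oc2ccc(NC(=O)N/N=C/c3ccccc3O[N+](=O)[O-])cc2F)ccn1` carries a 2-(nitrooxy)phenyl, and in this assay compound 2 gives 1200 nM; the difference, a 1.2-fold lower number from compound 1 to compound 2 (0.07 log units; within the scatter), is no real change. Compound 3 `COc1cc(/C=N/NC(=O)Nc2ccc(Oc3ccnc(-c4nncn4CCN(C)C)c3)c(F)c2)cc(OC)c1OC` carries a 3,4,5-trimethoxyphenyl. In this assay compound 3 gives only a limit, > 100000 nM. Both routes to it are large losses: an at least 70-fold higher number from compound 1 to compound 3 (1.85 log units; beyond the scatter) and an at least 83-fold higher number from compound 2 to compound 3 (1.92 log units; beyond the scatter). Compound 3 therefore stands as the weakest of the three, at the edge of what the assay reports: the limit of > 100000 nM in this assay, at which 1 of the 3 values shown sits.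

Compound 4 `COc1ccc(/C=N/NC(=O)Nc2ccc(Oc3ccnc(-c4nncn4CCN(C)C)c3)c(F)c2)cc1O` is not yet measured. It differs from compound 3 in one place: 3-hydroxy-4-methoxyphenyl in place of 3,4,5-trimethoxyphenyl on a carbon with a double bond to nitrogen. Among the compounds with values here, no measured step covers this exact swap; the two steps available only show that the 3,4,5-trimethoxyphenyl cost a great deal wherever it entered. Compound 4 keeps part of that ring and adds a hydroxyl, so a partial recovery is conceivable but unproven. Because compound 3 sits at a limit > 100000 nM, the expected step of an at least 1.6-fold lower number from compound 3 to compound 4 (0.22 log units; that floor lies within the scatter) is itself uncertain. Compound 4 is expected to give about 60000 nM in this assay, within 15000 nM to 300000 nM, with a real chance that only a limit is reported again.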

Compound 4, half-maximal inhibitory concentration: > 100000 nM
Compound 4 gave a limit, no number; the forecaster's own chance of this, stated with the estimate: 45%; middle value at least 1.6-fold (0.22 log units) from the limit.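

In this assay, the large loss is no longer tied to the 3,4,5-trimethoxyphenyl alone, as the 3-hydroxy-4-methoxyphenyl of compound 4 also falls far short of the two readable compounds: an at least 83-fold higher number from compound 2 to compound 4 (1.92 log units; beyond the scatter) and an at least 70-fold higher number from compound 1 to compound 4 (1.85 log units; beyond the scatter). Swapping the 3,4,5-trimethoxyphenyl for this smaller ring with one hydroxyl therefore brings no readable recovery, and the step between compound 3 and compound 4 cannot be read, both values being limits of the assay rather than numbers. Among these four compounds, the two rings carrying a methoxy group now stand apart from the 2,6-dichlorophenyl and the 2-(nitrooxy)phenyl, and they share one reported limit: the limit of > 100000 nM in this assay, at which 2 of the 4 values shown sit.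

On these data alone, how far compound 3 and compound 4 lie past that limit remains unknown, so no order can be set between them. Also open, as far as these compounds go, is whether the methoxy group itself goes with the loss, a question that a plain phenyl, a phenyl with a single chlorine, or a phenyl carrying an amine at this position could begin to answer.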